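Ethyl in place of phenyl: a step from compound 3

The compounds below may be only part of what the source reports. "The series", "measured", "known", "first", "only" and "open" are said of these compounds alone.

Of the compounds shown here, three sharing one core have been tested in a functional assay on HCT-116 cells (Homo sapiens) for antiproliferative activity, read by CCK-8 assay, with a stated time of 72 h, tested at 2 uM; on this read-out lower numbers stand for a weaker effect and higher numbers for a stronger effect at the one concentration tested. Compound 1 `Nc1ccccc1NC(=O)c1ccc(Cn2cnc3c(Nc4ccccc4)nc(Cl)nc32)cc1` gives 71.4%. Compound 2 `Nc1ccccc1NC(=O)/C=C/c1ccc(Cn2cnc3c(NCc4ccccc4)nc(Cl)nc32)cc1` gives 2.85%. Compound 3 `Nc1ccccc1NC(=O)c1ccc(CNc2nc(Cl)nc3c2ncn3Cc2ccccc2)cc1` gives 7.7%. Among these three numbers compound 3 stands second highest; its nearest neighbour is compound 2, whose number lies lower by an amount within the scatter, so the two cannot be told apart, while compound 1 lies far above compound 3, beyond the scatter.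

The unmeasured compound 4 `CCCn1cnc2c(NCc3ccc(C(=O)Nc4ccccc4N)cc3)nc(Cl)nc21` differs from compound 3 in one place: ethyl in place of phenyl on a saturated chain carbon bound to an aromatic nitrogen. Cut one bond further out, the same difference reads benzyl to propyl.

Within the data shown here, no measured pair differs by this change alone, so there is no step to lean on. Among the measured compounds shown here, the change removes a ring and leaves the remainder of compound 3 untouched, and the only near comparison available, compounds 2 and 3, shows that two rather different structures can sit within the scatter of each other at this low level. The expected step is a number 0.3 percentage points higher from compound 3 to compound 4 (within the scatter), which is none beyond the scatter. Compound 4 is therefore expected to give 8%, within a range from 0% to 25%.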

Compound 4, a percentage reported as inhibition, at one concentration (the size of the read-out at that concentration, not a potency): 28.5%
For compound 4 the middle estimate is 20.5 percentage points below the measured one; the whole stated range lies below it.
By their numbers in this assay, from the lowest: compounds 2 and 3 (each within the scatter of the next); then compound 4; then compound 1.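

In this assay, this position responds to a change of group: ethyl in place of phenyl on a saturated chain carbon bound to an aromatic nitrogen gives a number 20.8 percentage points higher from compound 3 to compound 4 (beyond the scatter), a modest step that no earlier pair could have shown. The phenyl ring is therefore not required at this position for the effect seen at the one concentration tested, as the propyl group, with no ring and fewer heavy atoms than benzyl, reads higher in this comparison. Nothing in the available information bears on why removing the ring raises the number, so the step stands as an observation only.

This single step cannot separate the loss of the aromatic ring from the presence of the open chain, and it does not show whether the rise would carry over to other compounds of this series. A methyl group, a longer chain such as butyl, a cyclohexylmethyl group or a chain ending in an amine at this position would each help to tell these readings apart.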